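The source may report more compounds than this note shows. Statements on the series, on what has been measured and on what is new or still open speak of the compounds shown alone.

Compound 1, `CCN(CC)c1ccc(NC(=O)c2c(-c3c(Cl)cccc3Cl)noc2C(C)C)cc1`, gives 861 nM in a functional assay on CHO-K cells with growth hormone secretagogue receptor type 1 (Homo sapiens) as the target, read by FLIPR; on this read-out higher numbers stand for weaker inhibition and lower numbers for stronger inhibition.
Compound 2, `CCN(CC)c1ccc(NC(=O)c2c(-c3c(Cl)cccc3Cl)noc2CCC2OCCCO2)cc1`, gives 19 nM in this assay.
Compound 3, `CCN(CC)c1ccc(NC(=O)c2c(-c3c(Cl)cccc3Cl)noc2CCC2CCCCO2)cc1`, gives 102 nM in this assay.

Compound 1 has the highest number of the three; compound 3 is nearest to it and compound 2 furthest, both beyond the scatter. Compound 4, `CCN(CC)c1ccc(NC(=O)c2c(-c3c(Cl)cccc3Cl)noc2CCC2OCCO2)cc1`, has not been measured. It differs from compound 1 in one place: 2-(1,3-dioxolan-2-yl)ethyl in place of isopropyl on an aromatic carbon. Going by the values given here, two measured steps bear on this change. In the step of a 45-fold lower number from compound 1 to compound 2 (1.66 log units; beyond the scatter) a six-membered non-aromatic ring with 2 hetero atoms was attached through a chain at the same aromatic carbon, and in the step of an 8.4-fold lower number from compound 1 to compound 3 (0.93 log units; beyond the scatter) a 2-(oxan-2-yl)ethyl group took the same place. Both lowered the number well beyond the scatter, and the step of a 5.4-fold higher number from compound 2 to compound 3 (0.73 log units; beyond the scatter) shows that the ring with 2 hetero atoms gave the stronger effect. Compound 4 carries a five-membered non-aromatic ring with 2 hetero atoms, so a large lowering is expected, a 25-fold lower number from compound 1 to compound 4 (1.39 log units; beyond the scatter). For compound 4 the estimated value is 35 nM, with a range from 10 nM to 120 nM.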

Compound 4, half-maximal inhibitory concentration: 56 nM
For compound 4 the middle estimate is 1.6-fold (0.20 log units) below the measured one; low and high end bracket the measured number.
By their numbers in this assay, from the lowest: compound 2; then compounds 4 and 3 (each within the scatter of the next); then compound 1.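

The 1,3-dioxolan-2-yl ring also works at this position, so the gain over isopropyl does not depend on a six-membered ring: there is a 15-fold lower number from compound 1 to compound 4 (1.19 log units; beyond the scatter). Ring size does count among the rings with two oxygens, since shrinking the ring of compound 2 gives a 2.9-fold higher number from compound 2 to compound 4 (0.47 log units; beyond the scatter). Against the oxan-2-yl ring, the change gives a 1.8-fold lower number from compound 3 to compound 4 (0.26 log units; within the scatter) and so lies within the scatter, which means these two groups cannot be told apart here.

No measurement shown here explains why these rings differ. As far as these compounds go, it also remains open whether a longer chain carrying the same 1,3-dioxolan-2-yl ring, or an amine such as morpholine in place of that ring, would keep the number this far below that of compound 1.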